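This account rests on a few compounds, and the source may have more. Where it says the series, first, only, none or still open, it means among the compounds named here.

In an ADME assay on THP-1 cells (Homo sapiens) for cytotoxicity, read by flow cytometry and propidium iodide staining, with a stated time of 72 h (on this read-out lower numbers stand for stronger inhibition and higher numbers for weaker inhibition), compound 1 (`CC(=O)Nc1ccc2oc(-c3ccccc3)cc(=O)c2c1`) gives 97000 nM and compound 2 (`Nc1ccc2oc(-c3ccc(F)cc3)cc(=O)c2c1`) gives 10000 nM. Compound 3 (`CC(=O)Nc1ccc2oc(-c3ccccc3)c(O)c(=O)c2c1`) gives 36000 nM, the second highest of these three numbers. Compound 4 (`COc1ccccc1-c1oc2ccc(NC(C)=O)cc2c(=O)c1O`) differs from compound 3 in one place: methoxy in place of hydrogen on an aromatic carbon, ortho to a large group. For the measured compounds named here, no measured step shows this change. The nearest evidence is a different change, hydroxy in place of hydrogen on an aromatic carbon, which gave a 2.7-fold lower number from compound 1 to compound 3 (0.43 log units; beyond the scatter), a modest step. No step beyond the scatter is therefore expected, in either direction, and the expected result is a 1.1-fold lower number from compound 3 to compound 4 (0.04 log units; within the scatter). Compound 4 is expected to give about 33000 nM, within an estimated range of 12000 nM to 85000 nM.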

Compound 4, half-maximal inhibitory concentration: > 125000 nM
Compound 4: no number, only a limit; the forecaster's own chance of this, stated with the estimate: 10%; at least 3.7-fold (0.57 log units) between middle value and limit.
By their numbers in this assay, from the lowest: compound 2; then compound 3; then compound 1. At a limit, above all of these: compound 4.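

In this assay, methoxy in place of hydrogen on an aromatic carbon, ortho to a large group, gives an at least 3.4-fold higher number from compound 3 to compound 4 (0.54 log units; beyond the scatter). This is the first shown change on the phenyl ring of this series, and it moves the number towards weaker inhibition, the opposite direction to a 2.7-fold lower number from compound 1 to compound 3 (0.43 log units; beyond the scatter). Compound 4 has only a limit, not a number: the limit of > 125000 nM in this assay, at which 1 of the 4 values shown sits.

On these data alone, it remains open whether methoxy on another carbon of this ring would give the same result. As far as these compounds go, it is also open how an amine or a carboxylic acid would read when placed ortho to a large group.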